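Trimming a Phenyl Thiourea to an Ethyl Thiourea

This account rests on a few compounds, and the source may have more. Where it says the series, first, only, none or still open, it means among the compounds named here.

Compound 1, `CN(C)/C(=N/CCCCn1nc(-c2ccccc2)ccc1=O)NC#N`: 30.3 mg/kg
Compound 2, `CC(C)(C)/N=C(\S)NCCCCn1nc(-c2ccccc2)ccc1=O`: > 100 mg/kg
Compound 3, `O=c1ccc(-c2ccccc2)nn1CCCCNC(=S)Nc1ccccc1`: > 100 mg/kg

In a functional assay on the whole organism (stomach) with Rattus norvegicus as the target (on this read-out higher numbers stand for an effect only at larger amounts of compound and lower numbers for an effect already at smaller amounts), compound 1 gives 30.3 mg/kg. Compound 2 reaches only a limit of the assay, > 100 mg/kg. Compound 3 likewise stops at a limit, > 100 mg/kg. Swapping the cyanoguanidine of compound 1 for a thiourea gave an at least 3.3-fold higher number from compound 1 to compound 2 (0.51 log units; beyond the scatter). The further change from compound 2 to compound 3, a step that the two limits leave unreadable from compound 2 to compound 3, cannot be sized, since both numbers are limits. Compound 3 therefore stands at the top of what was measured, sharing the limit of > 100 mg/kg in this assay, at which 2 of the 3 values shown sit, with compound 2.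

Compound 4, `CC/N=C(\S)NCCCCn1nc(-c2ccccc2)ccc1=O`, differs from compound 3 by a group of 5 heavy atoms (3 carbon, 1 nitrogen, 1 sulfur; no ring) in place of a group of 9 heavy atoms (7 carbon, 1 nitrogen, 1 sulfur; one six-membered aromatic ring of carbon only), on an amine nitrogen. Going by the values given here, the only steps that bear on this are those involving the thioureas, compounds 2 and 3, and both of them sit at the limit, so there is no measured step that shows a thiourea with a small alkyl group reaching a readable number. Compound 4 is therefore expected to remain at or near the limit, with an estimate of 120 mg/kg (35 mg/kg to 400 mg/kg). The expected step is a step that the limit leaves unreadable from compound 3 to compound 4, likely no change beyond the scatter.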

Compound 4, dose for half-maximal effect: 37.2 mg/kg
Compound 4: the middle estimate sits 3.2-fold (0.51 log units) above what was measured; low and high end bracket the measured number.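

Trimming the phenyl thiourea to the ethyl thiourea in this assay gives an at least 2.6-fold lower number from compound 3 to compound 4 (0.42 log units; beyond the scatter), and ethyl in place of tert-butyl gives an at least 2.6-fold lower number from compound 2 to compound 4 (0.42 log units; beyond the scatter). Both steps are only minimum sizes, because compounds 2 and 3 stop at a limit: the limit of > 100 mg/kg in this assay, at which 2 of the 4 values shown sit. The thiourea itself also does not rule out a readable effect: set against the cyanoguanidine, the ethyl thiourea shows a 1.2-fold higher number from compound 1 to compound 4 (0.09 log units; within the scatter), which leaves the two level on this read-out.

With only one thiourea giving a readable number, no trend across the groups on the thiourea can be drawn. The compounds shown leave open whether methyl or propyl in place of ethyl would give a lower number, and whether a shorter or longer chain to the core would keep the effect.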